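Trifluoromethyl to cyano: the step to compound 3

The source may hold more compounds than are shown below. What is called first, only, known or untested is meant among the compounds shown, and "the series" means these compounds.

Among the compounds with values here, in a functional assay (aorta) for inhibition, with Rattus norvegicus as the target (a higher number here means a weaker inhibitor, a lower number a stronger inhibitor), compound 2 (`Cc1nsc(-c2ccc(N3CCN(c4cccc(C(F)(F)F)c4)CC3)nn2)n1`) gives 0.3 nM and is the only compound with a single number. Compound 1 (`CN(C)c1nsc(-c2ccc(N3CCN(c4cccc(C(F)(F)F)c4)CC3)nn2)n1`) has two entries that sit far apart, as compound 1 reads 0.4 nM; 6 nM (2 entries) in this assay and offers no firm reference point.

Compound 3 (`Cc1nsc(-c2ccc(N3CCN(c4cccc(C#N)c4)CC3)nn2)n1`) keeps the rest of compound 2 and carries cyano in place of trifluoromethyl on an aromatic carbon, meta to a large group (cyano in place of trifluoromethyl on an aromatic carbon). Within the data shown here, no measured step covers this change, so the expectation is only a rough one. A modest shift towards weaker inhibition in this assay is expected, though a result within the scatter of compound 2 would be no surprise. The estimated change is a 2.7-fold higher number from compound 2 to compound 3 (0.43 log units; beyond the scatter) and no more. For compound 3 the expected value is 0.8 nM in a range from 0.15 nM to 5 nM.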

Compound 3, half-maximal inhibitory concentration: 3 nM
Compound 3: middle estimate off by 3.8-fold (0.57 log units), on the low side; low and high end bracket the measured number.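

In this assay, within the data shown here, the position carrying trifluoromethyl on the aromatic carbon proves sensitive to replacement, which the earlier compounds could not show because both carry that group: cyano in place of trifluoromethyl gives a 10-fold higher number from compound 2 to compound 3 (1.00 log units; beyond the scatter). Among these compounds, this is the only measured step at this place, and it runs towards weaker inhibition, with the entering group holding fewer heavy atoms and a hydrogen-bond acceptor that the leaving group lacks. The size of the step should still be read with care, as it rests on single entries and repeat entries can lie far apart: the several entries of compound 1 in this assay, 0.4 nM; 6 nM (2 entries)

One step cannot separate the loss of trifluoromethyl from the arrival of cyano, and a chlorine atom, a methoxy group or an amine on the same aromatic carbon would bear on that question. Going by these compounds, whether the same change carries over to the core of compound 1 also stays open.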